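The source may hold more compounds than are shown below. What is called first, only, known or untested is meant among the compounds shown, and "the series" means these compounds.

Measured in a functional assay on cells (leukaemia cell line, Homo sapiens) for inhibition, read by sulforhodamine B assay, with a stated time of 48 h; on this read-out lower numbers stand for stronger inhibition of growth and higher numbers for weaker inhibition of growth:
- compound 1 `O=S(=O)(Nc1ccc(Cl)c(Cl)c1)c1ccc(-c2cnc(C3CC3)o2)cc1`: 62100 nM
- compound 2 `O=S(=O)(Nc1ccc(Cl)c(F)c1)c1ccc(-c2cnc(C3CC3)o2)cc1`: 63000 nM

For the measured compounds named here, compound 2, at 63000 nM, lies within the scatter of compound 1, the only other measured value. The next analogue, compound 3 `O=S(=O)(Nc1cccc(Cl)c1)c1ccc(-c2cnc(C3CC3)o2)cc1`, carries 3-chlorophenyl in place of 4-chloro-3-fluorophenyl on a sulfonamide nitrogen.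

Going by the values given here, only one measured step bears on this change: a 1.0-fold higher number from compound 1 to compound 2 (0.01 log units; within the scatter), with fluoro in place of chloro on an aromatic carbon. Among the compounds with values here, that step exchanged one halogen for another, and the data hold no step in which a halogen is lost, so it is only a loose guide. Within the data shown here, with a 1.0-fold higher number from compound 1 to compound 2 (0.01 log units; within the scatter) as the sole precedent, no shift beyond the scatter is expected in this assay. The estimated step is a 1.0-fold higher number from compound 2 to compound 3 (0.01 log units; within the scatter).

Compound 3 is expected at 65000 nM, with an estimated range of 35000 nM to 100000 nM.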

Compound 3, concentration for total growth inhibition: 54200 nM
Estimate against measurement, compound 3: 1.2-fold (0.08 log units) above, and the stated range covers the measured number.
By their numbers in this assay, from the lowest: compounds 3, 1 and 2 (each within the scatter of the next).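

In this assay, the loss of a halogen can now be read, where the earlier pair showed only one halogen exchanged for another: 3-chlorophenyl in place of 4-chloro-3-fluorophenyl on a sulfonamide nitrogen gives one such step (a 1.2-fold lower number from compound 2 to compound 3 (0.07 log units; within the scatter)), and the removal of a single chloro group gives another (a 1.1-fold lower number from compound 1 to compound 3 (0.06 log units; within the scatter)). Both steps lie within the scatter, so at this position the read-out does not separate compound 1, compound 2 and compound 3. No evidence is available that bears on why these numbers stay together.

Still open, from the compounds shown here alone, is whether a phenyl ring carrying no halogen at all, or one carrying an amine or a carboxylic acid, would move the number beyond the scatter. Going by these compounds, a longer chain in place of the aryl group on the sulfonamide nitrogen is equally open.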